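Halogen swap on the benzyl group across two cores

The source may hold more compounds than are shown below. What is called first, only, known or untested is meant among the compounds shown, and "the series" means these compounds.

Measured compounds:
Compound 1 `Fc1ccc(CSc2nnc(-c3cnccn3)s2)cc1` gives 10100 nM in a functional assay on HepG2 cells (Homo sapiens) for antiproliferative activity, read by MTT assay, with a stated time of 48 h; a higher number here means a weaker inhibitor, a lower number a stronger inhibitor.
Compound 2 `Clc1ccc(CSc2nnc(-c3cnccn3)s2)cc1` gives 6230 nM in this assay.
Compound 3 `Fc1ccc(CSc2nnc(-c3cnccn3)n2-c2ccccc2)cc1` gives 10100 nM in this assay.

Compound 1 and compound 2 share one core and differ only in the halogen on the benzyl ring: chloro in place of fluoro on an aromatic carbon. The step that goes with this is a 1.6-fold lower number from compound 1 to compound 2 (0.21 log units; within the scatter), so the two numbers cannot be told apart with confidence.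

Compound 3 carries the same 4-fluorobenzyl group on a second core; how that core differs from the core of compound 1 is not broken down here. In this assay compound 3 gives 10100 nM, which is level with compound 1 at the digits shown, and the two together stand at the high end of the three numbers; compound 2 is the furthest from compound 3, yet even that gap stays within the scatter.

Compound 4 `Clc1ccc(CSc2nnc(-c3cnccn3)n2-c2ccccc2)cc1` has not been measured. It is related to compound 3 by chloro in place of fluoro on an aromatic carbon, the same change as that from compound 1 to compound 2, made at the same place on the benzyl ring. The only calibration available is the step of a 1.6-fold lower number from compound 1 to compound 2 (0.21 log units; within the scatter) on the first core, and the expectation rests on that single step and on compound 3 standing level with compound 1. The expected step is a 1.6-fold lower number from compound 3 to compound 4 (0.19 log units; within the scatter), a change that would itself sit within the usual scatter. The estimate for compound 4 in this assay is 6500 nM, with a range from 3000 nM to 14000 nM, the width reflecting that one step on a different core is all the evidence there is.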

Compound 4, half-maximal inhibitory concentration: 15300 nM
Compound 4: middle estimate off by 2.4-fold (0.37 log units), on the low side, and the stated range ends below it.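

In this assay, the swap of chloro for fluoro on the second core gives a 1.5-fold higher number from compound 3 to compound 4 (0.18 log units; within the scatter), and set beside the same swap on the first core it reads: the same change on two cores in this assay, a 1.6-fold lower number (0.21 log units; within the scatter) from compound 1 to compound 2 and a 1.5-fold higher number (0.18 log units; within the scatter) from compound 3 to compound 4, 2.5-fold (0.39 log units) apart, within the scatter of two such steps Neither step, nor the gap between them, lies beyond the scatter, so the opposite directions of the two steps cannot be read as a reversal, and nothing here shows that the core alters the outcome of this change. Nor do the steps show that a real effect carries from one core to the other, since on each core the 4-fluorobenzyl and 4-chlorobenzyl compounds cannot be told apart with confidence, leaving no measured effect to transfer.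

The compounds shown cover only two halogens at a single place on the benzyl ring, so it remains open whether a different group there, such as a methoxy, a nitrile, an amine or a carboxylic acid, would give a step beyond the scatter on either core. On these data alone, it also remains open whether a longer chain in place of the benzyl group would move the numbers on these two cores, and whether it would do so equally on both.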